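The source may report more compounds than this note shows. Statements on the series, on what has been measured and on what is new or still open speak of the compounds shown alone.

Measured in an ADME assay on the whole organism (plasma) for pharmacokinetics, with Rattus norvegicus as the target; a higher number here means faster removal of the compound, a lower number slower removal:
Compound 1 `O=S(=O)(c1ccc(F)cc1)c1cc(Cl)c(O)c2ncccc12`: 0.31 mL/min/kg
Compound 2 `O=S(=O)(c1cc(Cl)c(O)c2ncccc12)C1CCCC1`: 0.3 mL/min/kg
Compound 3 `O=S(=O)(c1cc(F)c(O)c2ncccc12)N1CCCC1`: 11 mL/min/kg

Compound 3 has the highest number of the three, beyond the scatter from both others. Compound 4 `O=S(=O)(c1cc(Cl)c(O)c2ncccc12)N1CCCC1` differs from it in one place: chloro in place of fluoro on an aromatic carbon, ortho to a hydroxy group. Among the compounds with values here, no measured step covers this swap directly. Within the data shown here, the one measured step, a 1.0-fold lower number from compound 1 to compound 2 (0.01 log units; within the scatter), changes only the group on the sulfonyl sulfur, with chloro kept. Compound 1, at 0.31 mL/min/kg, and compound 2, at 0.3 mL/min/kg, both carry chloro, but they also differ from compound 3 on the sulfonyl sulfur, so those gaps mix two changes. A drop in this assay is therefore expected, of uncertain size. The estimated step is a 5.5-fold lower number from compound 3 to compound 4 (0.74 log units; beyond the scatter). Compound 4 is expected at 2 mL/min/kg, within a range of 0.4 mL/min/kg to 9 mL/min/kg.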

Compound 4, clearance: 1 mL/min/kg
Beside the measured number, compound 4's estimate is 2.0-fold (0.30 log units) above it, and the stated range covers the measured number.
By their numbers in this assay, from the lowest: compounds 2 and 1 (each within the scatter of the next); then compound 4; then compound 3.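

In this assay, within the data shown here, chloro in place of fluoro on an aromatic carbon, ortho to a hydroxy group, gives an 11-fold lower number from compound 3 to compound 4 (1.04 log units; beyond the scatter), the first direct reading of this swap, with pyrrolidin-1-yl held on the sulfonyl sulfur. With chloro kept, the sulfur group also counts, by a smaller step: pyrrolidin-1-yl gives a 3.3-fold higher number from compound 2 to compound 4 (0.52 log units; beyond the scatter) and a 3.2-fold higher number from compound 1 to compound 4 (0.51 log units; beyond the scatter). No accompanying measurement explains these shifts.

Fluoro appears here only with pyrrolidin-1-yl, leaving open whether the swap is as large with cyclopentyl or 4-fluorophenyl. As far as these compounds go, how bromo or a nitrile would read on that carbon also remains open.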